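A Primary Amine on the Sulfur Chain of Compound 1

The source may hold more compounds than are shown below. What is called first, only, known or untested is meant among the compounds shown, and "the series" means these compounds.

Compound 1 `CSc1nc(NCc2ccc(-c3ccccn3)cc2)c2[nH]nc(C(C)C)c2n1` gives 783 nM in a functional assay on HT cells (Homo sapiens) for antiproliferative activity, read by fluorescence, with a stated time of 72 h (on this read-out lower numbers stand for stronger inhibition of growth and higher numbers for weaker inhibition of growth), the highest of the three numbers in hand. Compound 2 `CC(C)c1n[nH]c2c(NCc3ccc(-c4ccccn4)cc3)nc(SCC(O)CN3CCNCC3)nc12` gives 332 nM in this assay, and compound 3 `CC(C)c1n[nH]c2c(NCc3ccc(-c4ccccn4)cc3)nc(SC3CCCCC3N)nc12` gives 139 nM. Compound 4 `CC(C)c1n[nH]c2c(NCc3ccc(-c4ccccn4)cc3)nc(SCCCN)nc12` differs from compound 1 in one place: 2-aminoethyl in place of hydrogen on a saturated chain carbon bound to a sulfur. Both earlier changes at the sulfur of compound 1 brought in an amine, and both lowered the number: a 2.4-fold lower number from compound 1 to compound 2 (0.37 log units; beyond the scatter) and a 5.6-fold lower number from compound 1 to compound 3 (0.75 log units; beyond the scatter). Compound 4 brings in a short chain with no ring and one amine, so a modest lowering of similar size is expected rather than none. For compound 4 the estimate in this assay is 260 nM, with a range from 120 nM to 550 nM. The expected step is a 3.0-fold lower number from compound 1 to compound 4 (0.48 log units; beyond the scatter).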

Compound 4, concentration for 50% growth inhibition: 120 nM
Compound 4: middle estimate off by 2.2-fold (0.34 log units), on the high side, and the stated range covers the measured number.
By their numbers in this assay, from the lowest: compounds 4 and 3 (each within the scatter of the next); then compound 2; then compound 1.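

In this assay, the 3-aminopropyl chain on the sulfur shows that this position needs no ring to reach the lower numbers: the step from the methyl group is large (a 6.5-fold lower number from compound 1 to compound 4 (0.81 log units; beyond the scatter)), and compound 4 stands level with the 2-aminocyclohexyl group of compound 3 (a 1.2-fold lower number from compound 3 to compound 4 (0.06 log units; within the scatter)). The 2-hydroxy-3-(piperazin-1-yl)propyl chain of compound 2 gives the higher number (a 2.8-fold lower number from compound 2 to compound 4 (0.44 log units; beyond the scatter)). No measurement offered here accounts for these steps. The compounds shown leave open whether the amine itself counts, which a hydroxyl or carboxylic acid at the end of this chain would test. From the compounds shown here alone, how a shorter or longer aminoalkyl chain would read also stays open.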